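Swapping a Sulfanyl Chain for Ethoxy on Compound 1

The source may report more compounds than this note shows. Statements on the series, on what has been measured and on what is new or still open speak of the compounds shown alone.

Of the compounds shown here, two have so far been measured in a functional assay on MV4-11 cells (Homo sapiens) for inhibition, read by resazurin assay, with a stated time of 72 h; a lower number here means a stronger inhibitor of growth, a higher number a weaker inhibitor of growth. Compound 1, `COCCSc1nc(C)c(-c2ccnc(Nc3ccc(OC)cc3OC)n2)s1`, gives 810 nM. Compound 2, `COc1ccc(Nc2nccc(-c3cn(C(C)C)c4ccccc34)n2)c(OC)c1`, gives 3250 nM in this assay. Compound 1 therefore holds the lower of the two numbers, and the gap to compound 2 lies beyond the usual scatter of this kind of measurement, so compound 1 is the stronger growth inhibitor of the pair.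

Compound 3, `CCOc1nc(C)c(-c2ccnc(Nc3ccc(OC)cc3OC)n2)s1`, has not yet been measured. It differs from compound 1 in a single place: ethoxy in place of (2-methoxyethyl)sulfanyl on an aromatic carbon. Among the compounds with values here, no measured pair shows a change of this kind, so there is no direct guide to how the number should move. The shared core and the methyl group on the five-membered aromatic ring stay the same, and only the group on the ring carbon next to the ring nitrogen and ring sulfur is exchanged.

For compound 3 in this assay a value of 1200 nM is expected, within a range from 400 nM to 4000 nM. This would be a step of a 1.5-fold higher number from compound 1 to compound 3 (0.17 log units; within the scatter), expected to be small and within the scatter.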

Compound 3, concentration for 50% growth inhibition: 3890 nM
For compound 3 the middle estimate is 3.2-fold (0.51 log units) below the measured one; low and high end bracket the measured number.
By their numbers in this assay, from the lowest: compound 1; then compounds 2 and 3 (each within the scatter of the next).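

Within the data shown here, this is the first measured change at this position, on the ring carbon next to the ring nitrogen and next to the ring sulfur. In this assay, exchanging (2-methoxyethyl)sulfanyl for ethoxy gives a 4.8-fold higher number from compound 1 to compound 3 (0.68 log units; beyond the scatter) and so a weaker inhibitor of growth, which shows that the number responds to the group on this carbon even though the rest of the molecule stays the same. No measurement shown here explains why the number rose.

The exchange alters both the atom that links the chain to the ring and the length of the chain, so this single step cannot show which of the two differences matters, or whether both do. Ethylsulfanyl, which keeps the sulfur with a shorter chain, and 2-methoxyethoxy, which keeps the full chain with an oxygen in place of the sulfur, would each separate these two differences, while an amine on the same carbon remains an open question too.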